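The source may report more compounds than this note shows. Statements on the series, on what has been measured and on what is new or still open speak of the compounds shown alone.

Compound 1 (`COc1cc(/C=C/C(=O)/C=C/c2cccc3ccccc23)ccc1OCc1cn(CCCOc2cc(=O)oc3ccccc23)nn1`), compound 2 (`COc1ccccc1/C=C/C(=O)/C=C/c1ccc(OCc2cn(CCCOc3cc(=O)oc4ccccc34)nn2)c(OC)c1`) and compound 3 (`COc1ccc(/C=C/C(=O)/C=C/c2ccc(OCc3cn(CCCOc4cc(=O)oc5ccccc45)nn3)c(OC)c2)cc1`) share most of their structure. In a functional assay on PC-3 cells (Homo sapiens) for inhibition, read by sulforhodamine B assay, with a stated time of 48 h, tested at 50 uM (a higher number here means more inhibition of growth at the concentration tested, a lower number less inhibition of growth), compound 1 gives 8% as its result. Compound 2 is recorded as "not active" (no number reported) with no number attached. Compound 3 is likewise recorded as "not active" (no number reported) with no number attached, so it has no single value to place on the scale, and compound 2 is the only other entry of that kind.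

Compound 4 (`COc1cc(/C=C/C(=O)/C=C/c2ccccc2)ccc1OCc1cn(CCCOc2cc(=O)oc3ccccc23)nn1`) has not yet been measured. It differs from compound 3 by one small edit (hydrogen in place of methoxy on an aromatic carbon), with hydrogen in place of methoxy on an aromatic carbon, turning 4-methoxyphenyl into phenyl. Going by the values given here, no measured pair shows the size of such a step. The expected step in this assay is none beyond the scatter, in either direction, judging from compound 3 at "not active" (no number reported) and compound 1 at 8% as the only nearby results. For compound 4 the estimated growth inhibition is 8% with an expected range of 0% to 22% in this test.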

Compound 4, percent growth inhibition at one concentration: "not active" (no number reported)
No number was reported for compound 4; there is nothing to compare the estimate with.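

Compound 3 and compound 4 both carry no number in this assay, so no step can be read between them. No evidence shown bears on this result. Going by these compounds, what replacing 4-methoxyphenyl with phenyl does to growth inhibition stays open, as does whether either compound differs from compound 1.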